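The source may hold more compounds than are shown below. What is called first, only, known or untested is meant among the compounds shown, and "the series" means these compounds.

Measured so far in an ADME assay on Vero cells (Chlorocebus sabaeus) for cytotoxicity, read by MTT assay, with a stated time of 72 h; a lower number here means that less compound is tolerated, a higher number that more compound is tolerated:
- Compound 1 `COC(=O)CCN1CCN(c2c(F)cc3c(=O)c(C(=O)O)cn(C4CC4)c3c2OC)CC1C` gives > 1000 ug/mL as a limit of the assay
- Compound 2 `CCOC(=O)CN1CCN(c2c(F)cc3c(=O)c(C(=O)O)cn(C4CC4)c3c2OC)CC1C` gives 1000 ug/mL as a plain number
- Compound 3 `CCOC(=O)CCN1CCN(c2c(F)cc3c(=O)c(C(=O)O)cn(C4CC4)c3c2OC)CC1C` gives "not determined" (no result reported) as its entry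

Compound 3 therefore has no single number in this assay and can only be placed through its relatives. Compound 4 `COc1c(N2CCN(CC(C)=O)C(C)C2)c(F)cc2c(=O)c(C(=O)O)cn(C3CC3)c12` carries acetyl in place of (ethoxycarbonyl)methyl on a saturated chain carbon bound to an amine nitrogen in a ring, counted as acetyl in place of (ethoxycarbonyl)methyl on a saturated chain carbon bound to an amine nitrogen in a ring against compound 3. Going by the values given here, the only measured step at this place, a number no higher from compound 1 to compound 2 (the limit leaves the size open), has no readable size and gives no direction for this change. Among the compounds with values here, with compound 2 at 1000 ug/mL as the one number available, no step beyond the usual scatter is expected. Compound 4 is estimated at 800 ug/mL in this assay, with an expected range from 350 ug/mL to 1200 ug/mL for repeated measurements.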

Compound 4, half-maximal cytotoxic concentration: 500 ug/mL
Compound 4: the middle estimate sits 1.6-fold (0.20 log units) above what was measured; the measured number falls inside the stated range.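

Going by these compounds alone, at this place, on a saturated chain carbon bound to an amine nitrogen in a ring, the compounds now give a first step of readable size in this assay: methyl in place of ethoxy on a carbonyl carbon gives a 2.0-fold lower number from compound 2 to compound 4 (0.30 log units; within the scatter). Acetyl in place of (methoxycarbonyl)methyl gives an at least 2.0-fold lower number from compound 1 to compound 4 (0.30 log units; that floor lies within the scatter). Compound 1 stands at a limit, so this step has only a floor: the limit of > 1000 ug/mL in this assay, at which 1 of the 4 values shown sits.

As far as these compounds go, what an amine or a carboxylic acid at this place would give stays open, as does whether a longer chain would move the value beyond the scatter.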